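The source may hold more compounds than are shown below. What is called first, only, known or untested is meant among the compounds shown, and "the series" means these compounds.

Measured so far in a functional assay on MCF7 cells (Homo sapiens) for antiproliferative activity, read by MTT assay, with a stated time of 72 h; on this read-out lower numbers stand for stronger inhibition and higher numbers for weaker inhibition:
compound 1 `CCCSc1nc(N/N=C/c2ccccc2F)c2nnn(Cc3ccccc3)c2n1` gives > 64000 nM, which is a limit of the assay.
compound 2 `CCCSc1nc(N/N=C(\C)c2ccccc2O)c2nnn(Cc3ccco3)c2n1` gives 29000 nM.
compound 3 `CCCSc1nc(N/N=C/c2cc(OC)c(OC)c(OC)c2)c2nnn(Cc3ccccc3)c2n1` gives > 64000 nM, which is a limit of the assay.

Compound 1 stands at the limit of > 64000 nM in this assay, at which 2 of the 3 values shown sit, so no number is available for it, only the limit. Going by the values given here, compound 2 carries the only numerical value among the three.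

Compound 4 `CCCSc1nc(N/N=C/c2cccnc2)c2nnn(Cc3ccccc3)c2n1` has not been measured in this assay. It differs from compound 1 by pyridin-3-yl in place of 2-fluorophenyl on a carbon with a double bond to nitrogen. Among the compounds with values here, no measured pair covers a change of this kind, so no step size can be drawn from the data. The expected step of a number no higher from compound 1 to compound 4 (the limit leaves the size open) is none beyond the scatter. Compound 4 is therefore estimated at 64000 nM, between 20000 nM and 200000 nM, and will most likely again be reported only as a limit.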

Compound 4, half-maximal inhibitory concentration: 58700 nM
For compound 4 the middle estimate is 1.1-fold (0.04 log units) above the measured one, within the range that was stated.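

On a carbon with a double bond to nitrogen, pyridin-3-yl gives compound 4 a numerical result rather than a limit, 58700 nM in this assay. Pyridin-3-yl in place of 2-fluorophenyl gives an at least 1.0-fold lower number from compound 1 to compound 4 (0.03 log units; that floor lies within the scatter). The true size of this step stays open because compound 1 is held only as a limit: the limit of > 64000 nM in this assay, at which 2 of the 4 values shown sit.

On these data alone, whether pyridin-4-yl or an aminophenyl group at this place would give a number clearly lower than that of compound 4 remains open.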